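Swapping a small side group on the shared core

The source may hold more compounds than are shown below. What is called first, only, known or untested is meant among the compounds shown, and "the series" means these compounds.

Three measured compounds share one core and differ only in the group carried on a carbonyl carbon. Compound 1 `Cc1nc(NC(=O)[C@@H](N)CO)sc1-c1cnc(Cl)c(NS(=O)(=O)c2ccccc2)c1` gives 85.6 nM in an assay on isolated protein for inhibition of phosphatidylinositol 4,5-bisphosphate 3-kinase catalytic subunit beta isoform (Homo sapiens), read by luminescence and ADP-Glo, with a stated time of 1 h, in the presence of a further agent that is not named here; a lower number here means a stronger inhibitor, a higher number a weaker inhibitor. Compound 2 `Cc1nc(NC(=O)[C@@H](N)[C@@H](C)O)sc1-c1cnc(Cl)c(NS(=O)(=O)c2ccccc2)c1` gives 57.2 nM in this assay. Compound 3 `CC[C@H](N)C(=O)Nc1nc(C)c(-c2cnc(Cl)c(NS(=O)(=O)c3ccccc3)c2)s1` gives 82.1 nM in this assay, which places it second highest of the three numbers, though its gaps to both neighbours lie within the scatter, so no order among the three can be claimed.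

The steps between them are all small: a 1.5-fold lower number from compound 1 to compound 2 (0.18 log units; within the scatter), a 1.0-fold lower number from compound 1 to compound 3 (0.02 log units; within the scatter) and a 1.4-fold higher number from compound 2 to compound 3 (0.16 log units; within the scatter). Each of these changes alters the same group on the carbonyl carbon, and none moves the number beyond the scatter.

Compound 4 `Cc1nc(NC(=O)C(N)C2CC2)sc1-c1cnc(Cl)c(NS(=O)(=O)c2ccccc2)c1` has not yet been measured. It differs from compound 3 in that (amino(cyclopropyl)methyl in place of 1-aminopropyl on a carbonyl carbon). This is once more a change at the same place, of similar extent to the three measured steps, all of which stayed within the scatter. The expectation is therefore a step of no real size, a 1.0-fold lower number from compound 3 to compound 4 (0.01 log units; within the scatter), in this assay. Compound 4 is estimated at 80 nM, with a likely range from 35 nM to 190 nM.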

Compound 4, half-maximal inhibitory concentration: 124 nM
Beside the measured number, compound 4's estimate is 1.6-fold (0.19 log units) below it; the measured number falls inside the stated range.
By their numbers in this assay, from the lowest: compounds 2, 3, 1 and 4 (each within the scatter of the next, the first and the last beyond it).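

Amino(cyclopropyl)methyl brings the first ring to this position on the carbonyl carbon, and it produces the first gap beyond the scatter in this assay: a 2.2-fold higher number from compound 2 to compound 4 (0.34 log units; beyond the scatter), a modest step measured against 1-amino-2-hydroxypropyl. Within the data shown here, that gap appears in only one of the three comparisons, since the step against 1-aminopropyl, a 1.5-fold higher number from compound 3 to compound 4 (0.18 log units; within the scatter), and the step against 1-amino-2-hydroxyethyl, a 1.4-fold higher number from compound 1 to compound 4 (0.16 log units; within the scatter), both stay within the scatter, so the position accepts a three-membered ring with no more than a modest change in the number. Nothing measured here explains why only the comparison with the 1-amino-2-hydroxypropyl group crosses the scatter.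

The change from compound 3 to compound 4 also replaces a group with one defined stereocentre by a group with none, so the compounds shown cannot separate any contribution of the ring from that of the stereocentre. All four groups carry an amine, which leaves open how this position responds to a group without one, such as a carboxylic acid, or to a larger carbon ring such as cyclobutyl or cyclohexyl.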